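This account rests on a few compounds, and the source may have more. Where it says the series, first, only, none or still open, it means among the compounds named here.

Compound 1 `O=c1nc(SCc2ccccc2)ccn1[C@@H]1O[C@H](COP(=O)(O)OP(=O)(O)O)[C@@H](O)[C@H]1O` — 800 nM
Compound 2 `C=CCSc1ccn([C@@H]2O[C@H](COP(=O)(O)OP(=O)(O)O)[C@@H](O)[C@H]2O)c(=O)n1` — 560 nM
Compound 3 `CCCCCCSc1ccn([C@@H]2O[C@H](COP(=O)(O)OP(=O)(O)O)[C@@H](O)[C@H]2O)c(=O)n1` — 4900 nM

These three compounds share one core and differ only in the group carried on the sulfur. In an in vitro functional assay on 1321-N1 cells for agonist activity at P2Y purinoceptor 6 (Homo sapiens) (on this read-out higher numbers stand for an effect only at larger amounts of compound and lower numbers for an effect already at smaller amounts), compound 3 stands highest of the three numbers, reached through a 6.1-fold higher number from compound 1 to compound 3 (0.79 log units; beyond the scatter) and an 8.8-fold higher number from compound 2 to compound 3 (0.94 log units; beyond the scatter). Compound 4 `O=C(O)CCSc1ccn([C@@H]2O[C@H](COP(=O)(O)OP(=O)(O)O)[C@@H](O)[C@H]2O)c(=O)n1` carries the change (carboxy in place of butyl on a saturated chain carbon, two bonds along the chain from a sulfur); read one bond further out, this is pentyl to carboxymethyl. Within the data shown here, no measured step involves a carboxy, so the two steps into compound 3 are the only guide: pentyl in place of phenyl or vinyl raised the number beyond the scatter, and compound 4 shortens that chain again. A lower number than compound 3 is therefore expected, a 3.3-fold lower number from compound 3 to compound 4 (0.51 log units; beyond the scatter), with real uncertainty from the untested carboxy. Compound 4 is estimated at 1500 nM, between 400 nM and 6000 nM.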

Compound 4, half-maximal effective concentration: 1100 nM
Compound 4: the middle estimate sits 1.4-fold (0.13 log units) above what was measured, and the stated range covers the measured number.
By their numbers in this assay, from the lowest: compounds 2, 1 and 4 (each within the scatter of the next); then compound 3.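

Replacing hexylsulfanyl with (2-carboxyethyl)sulfanyl in this assay reverses much of what the long chain cost (a 4.5-fold lower number from compound 3 to compound 4 (0.65 log units; beyond the scatter)). A chain ending in a carboxy is therefore accepted at this position, with the steps from the vinyl and phenyl compounds staying within the scatter (a 2.0-fold higher number from compound 2 to compound 4 (0.29 log units; within the scatter); a 1.4-fold higher number from compound 1 to compound 4 (0.14 log units; within the scatter)). Nothing measured here explains this.

The shorter chain and the carboxy changed together, so their shares stay unseparated. A plain propyl chain, or an equally long chain ending in an amine, would tell them apart.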